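A few compounds are considered here, and "the series" means these few. Any claim that something is new, unique, unknown or untested is made for them only; others in the source may bear on it.

Measured so far:
- Compound 1, `O=C(O)CCCO/N=c1/ccn([C@@H]2O[C@H](COP(=O)(O)OP(=O)(O)OP(=O)(O)O)[C@@H](O)[C@H]2O)c(=O)[nH]1`: 299 nM
- Compound 2, `O=c1[nH]/c(=N\OCCOc2ccccc2)ccn1[C@@H]1O[C@H](COP(=O)(O)OP(=O)(O)OP(=O)(O)O)[C@@H](O)[C@H]1O`: 3400 nM
- Compound 3, `COc1ccc(CCCO/N=c2/ccn([C@@H]3O[C@H](COP(=O)(O)OP(=O)(O)OP(=O)(O)O)[C@@H](O)[C@H]3O)c(=O)[nH]2)cc1`: 47 nM

All three were tested in a functional assay on 1321-N1 cells for agonist activity at P2Y purinoceptor 2 (Homo sapiens), read by scintillation counting and inositol phosphate accumulation; a lower number here means that less compound is needed, a higher number that more compound is needed for the effect. Among them compound 2 has the highest number: compound 1 sits nearest, with an 11-fold higher number from compound 1 to compound 2 (1.06 log units; beyond the scatter) separating the two, and compound 3 furthest, with a 72-fold lower number from compound 2 to compound 3 (1.86 log units; beyond the scatter) between them. Compound 2 is thus the weakest agonist of the three, and the two steps into and out of it are both beyond the scatter.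

Compound 4, `C#CCCCO/N=c1/ccn([C@@H]2O[C@H](COP(=O)(O)OP(=O)(O)OP(=O)(O)O)[C@@H](O)[C@H]2O)c(=O)[nH]1`, has not yet been measured in this assay. Its change from compound 2 is propargyl in place of phenoxy on a saturated chain carbon, two bonds along the chain from an oxygen. The two steps that touch compound 2 show that swapping the group at this position moves the number a long way in either direction, so a change beyond the scatter is expected here too. Since compound 1, which carries a small non-aromatic tail at the same place, gives 299 nM, compound 4 is expected to land in that neighbourhood, and the step of a 6.8-fold lower number from compound 2 to compound 4 (0.83 log units; beyond the scatter) is estimated to be downward. For compound 4 the estimate is 500 nM, with a range from 120 nM to 2000 nM.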

Compound 4, half-maximal effective concentration: 168 nM
For compound 4 the middle estimate is 3.0-fold (0.47 log units) above the measured one; low and high end bracket the measured number.
By their numbers in this assay, from the lowest: compound 3; then compounds 4 and 1 (each within the scatter of the next); then compound 2.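

In this assay the swap of phenoxy for propargyl gives a 20-fold lower number from compound 2 to compound 4 (1.31 log units; beyond the scatter) and so shows that an aromatic ring at this place is not needed for a low number. A ring can still help, though, since the ethynyl chain end stays behind the 4-methoxyphenyl chain end with a 3.6-fold higher number from compound 3 to compound 4 (0.55 log units; beyond the scatter) as the step. Against the carboxy chain end the step is a 1.8-fold lower number from compound 1 to compound 4 (0.25 log units; within the scatter) and the two ends cannot be told apart here, although one holds a triple bond and the other an acid.

No measurement shown gives a reason for any of these steps. Going by these compounds, it also stays open whether a longer chain ending in the same triple bond, or an amine at the end of the chain, would keep the number at this level.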